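An ester in place of a ketone on the shared core

The source may report more compounds than this note shows. Statements on the series, on what has been measured and on what is new or still open speak of the compounds shown alone.

Compound 1 `CC(=O)Cn1nnc(Cc2ccc(-c3ccccc3)cc2)n1` in an assay on isolated protein (COS cells) for inhibition of diacylglycerol lipase-alpha (Homo sapiens) (on this read-out lower numbers stand for stronger inhibition and higher numbers for weaker inhibition), gives > 10000 nM, a limit of the assay.
Compound 2 `COC(=O)Cn1nnc(Cc2ccc(-c3ccccc3)cc2)n1` gives > 10000 nM, a limit of the assay.
Compound 3 `CC(=O)Cn1nnc(CNC(=O)c2ccc(-c3ccccc3)cc2)n1` gives > 10000 nM, a limit of the assay.

Compound 3 thus stands only at a limit in this assay, as do the two other measured compounds; all three sit at the limit of > 10000 nM in this assay, at which 3 of the 3 values shown sit. Compound 4 `COC(=O)Cn1nnc(CNC(=O)c2ccc(-c3ccccc3)cc2)n1` differs from compound 3 by methoxy in place of methyl on a carbonyl carbon. Among the compounds with values here, the one measured step of the same kind, a step that the two limits leave unreadable from compound 1 to compound 2, runs between two limits, so its size cannot be read. Nothing measured here therefore points to a step beyond the scatter in this assay, and a further limit is the likeliest outcome. Compound 4 is expected at 30000 nM, between 8000 nM and 120000 nM. The expected step is a step that the limit leaves unreadable from compound 3 to compound 4.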

Compound 4, half-maximal inhibitory concentration: > 10000 nM
Compound 4 ended at the assay's limit; the forecaster's own chance of this, stated with the estimate: 85%; the middle value lies beyond the limit too.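

Compound 3 and compound 4 both stand at a limit in this assay, so the step between them cannot be read: the limit of > 10000 nM in this assay, at which 4 of the 4 values shown sit. The compounds shown leave open whether methoxy in place of methyl on a carbonyl carbon changes inhibition at all.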